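Cinnamamide quinazoline series: cytotoxicity notes on a bromophenyl analogue

This account rests on a few compounds, and the source may have more. Where it says the series, first, only, none or still open, it means among the compounds named here.

Measured so far:
compound 1 `COc1ccc(OC)c(/C=C/C(=O)Nc2cc3c(Nc4ccc(F)c(Cl)c4)ncnc3cc2O[C@H]2CCOC2)c1` 7300 nM
compound 2 `COc1cc(/C=C/C(=O)Nc2cc3c(Nc4ccc(F)c(Cl)c4)ncnc3cc2O[C@H]2CCOC2)cc(OC)c1` 10800 nM

In a functional assay on A549 cells (Homo sapiens) for cytotoxicity, read by MTT assay, with a stated time of 72 h (a higher number here means a weaker inhibitor, a lower number a stronger inhibitor), compound 2 gives 10800 nM, the highest of the two numbers, with compound 1 nearest, a step of a 1.5-fold higher number from compound 1 to compound 2 (0.17 log units; within the scatter) away, which lies within the scatter. Compound 3 `O=C(/C=C/c1ccc(Br)cc1)Nc1cc2c(Nc3ccc(F)c(Cl)c3)ncnc2cc1O[C@H]1CCOC1` is not yet measured in this assay. The change from compound 2 to compound 3 is 4-bromophenyl in place of 3,5-dimethoxyphenyl on a double-bonded chain carbon bound to a double-bonded chain carbon. Among the measured compounds shown here, no measured step bears on this change: the only step in hand, a 1.5-fold higher number from compound 1 to compound 2 (0.17 log units; within the scatter), concerns a shift of methoxy groups within the same ring and is itself within the scatter, so it gives no direction for exchanging the whole ring. The working expectation for compound 3 is therefore no step beyond the scatter in this assay. Compound 3 is estimated at 9000 nM, with a range of 3000 nM to 30000 nM. The expected step from compound 2 is a 1.2-fold lower number from compound 2 to compound 3 (0.08 log units; within the scatter), though the range is wide since nothing measured constrains it.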

Compound 3, half-maximal inhibitory concentration: 35300 nM
Compound 3: middle estimate off by 3.9-fold (0.59 log units), on the low side; measured number above the stated range.
By their numbers in this assay, from the lowest: compounds 1 and 2 (each within the scatter of the next); then compound 3.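

In this assay the aryl group on the double-bonded chain carbon now shows a step beyond the scatter, which the shift of methoxy groups within the ring did not show. Exchanging the whole ring for 4-bromophenyl gives a 3.3-fold higher number from compound 2 to compound 3 (0.51 log units; beyond the scatter) and a 4.8-fold higher number from compound 1 to compound 3 (0.68 log units; beyond the scatter) in the same direction from both dimethoxyphenyl compounds, which makes compound 3 the weakest inhibitor of the three. No measurement in hand explains this change.

The compounds shown do not separate the effect of adding the bromine from that of losing the two methoxy groups, as the change does both at once. Also open, from the compounds shown here alone, is how a phenyl ring carrying a single methoxy group, or an amine in place of the bromine, would read in this assay on this same chain.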